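Trifluoromethyl Gives Way to Methyl on the Phenyl

The compounds below may be only part of what the source reports. "The series", "measured", "known", "first", "only" and "open" are said of these compounds alone.

Three compounds share one core and differ only in the group carried on the aromatic nitrogen. Compound 1 `C/C(=C\CC/C(C)=C/CC[C@@H]1[C@@]2(C)CCC(=O)C(C)(C)[C@H]2CC[C@@]1(C)O)CC/C=C(\C)C(=O)OCc1cn(-c2ccccc2C)nn1` bears 2-methylphenyl there, compound 2 `COc1cccc(-n2cc(COC(=O)/C(C)=C/CC/C(C)=C/CC/C(C)=C/CC[C@@H]3[C@@]4(C)CCC(=O)C(C)(C)[C@H]4CC[C@@]3(C)O)nn2)c1` bears 3-methoxyphenyl, and compound 3 `C/C(=C\CC/C(C)=C/CC[C@@H]1[C@@]2(C)CCC(=O)C(C)(C)[C@H]2CC[C@@]1(C)O)CC/C=C(\C)C(=O)OCc1cn(-c2cccc(C(F)(F)F)c2)nn1` bears 3-(trifluoromethyl)phenyl. In a functional assay on DU-145 cells (Homo sapiens) for antiproliferative activity, read by MTT assay, with a stated time of 48 h (a higher number here means a weaker inhibitor, a lower number a stronger inhibitor), compound 1 gives no number but only a limit, > 150000 nM. In this assay compound 2 likewise gives only a limit, > 150000 nM. Compound 3 in this assay also stands at a limit, > 150000 nM. Because every value sits at the limit of > 150000 nM in this assay, at which 3 of the 3 values shown sit, the steps a step that the two limits leave unreadable from compound 1 to compound 2, a step that the two limits leave unreadable from compound 1 to compound 3 and a step that the two limits leave unreadable from compound 2 to compound 3 carry no readable size, and compound 3 cannot be placed above or below its two companions.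

Compound 4 `C/C(=C\CC/C(C)=C/CC[C@@H]1[C@@]2(C)CCC(=O)C(C)(C)[C@H]2CC[C@@]1(C)O)CC/C=C(\C)C(=O)OCc1cn(-c2cccc(C)c2)nn1` is compound 3 with methyl in place of trifluoromethyl on an aromatic carbon; cut one bond further out, the same change reads 3-(trifluoromethyl)phenyl to 3-methylphenyl. Going by the values given here, no measured step bears on this change with a readable size: the three steps among compounds 1, 2 and 3 are all hidden by the limit. With three varied phenyl substituents giving nothing but limits, the step that the limit leaves unreadable from compound 3 to compound 4 is expected to be none beyond the scatter, most likely ending again at a limit. Compound 4 is therefore estimated at about 200000 nM, somewhere between 80000 nM and 500000 nM.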

Compound 4, half-maximal inhibitory concentration: 137000 nM
The estimate for compound 4 lay 1.5-fold (0.16 log units) above the measured number; the measured number falls inside the stated range.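

Going by these compounds alone, with 3-methylphenyl on the aromatic nitrogen, compound 4 is the only one of the four compounds to give an actual number in this assay, 137000 nM.

Compounds 1, 2 and 3 stop short of a number: the limit of > 150000 nM in this assay, at which 3 of the 4 values shown sit.

Three steps that would otherwise carry no information now have a direction and a floor: an at least 1.0-fold lower number from compound 3 to compound 4 (0.03 log units; that floor lies within the scatter), an at least 1.0-fold lower number from compound 2 to compound 4 (0.03 log units; that floor lies within the scatter) and an at least 1.0-fold lower number from compound 1 to compound 4 (0.03 log units; that floor lies within the scatter). Each floor stays within the scatter, so methyl in place of trifluoromethyl at this position cannot yet be called a real gain, and the same holds for the changes from methoxy and from 2-methylphenyl.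

Going by these compounds, the true values of compounds 1, 2 and 3 remain open, so the real size of each of these steps is unknown, and the steps among those three compounds still cannot be read. Also open, on these data alone, is whether an amine or a carboxylic acid in place of the methyl on this phenyl ring would move the number clearly beyond the scatter.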